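Aminomethyl to hydroxymethyl on the benzylic arm

The compounds below may be only part of what the source reports. "The series", "measured", "known", "first", "only" and "open" are said of these compounds alone.

For the measured compounds named here, compound 2 `NCc1ccc(CN(Cc2nc3ccccc3[nH]2)C2CCCc3cccnc32)c(CN)c1` gives the lowest of the two numbers measured so far in a functional assay on CEM-CCRF cells for antagonist activity at C-X-C chemokine receptor type 4 (Homo sapiens), read by calcium flux (on this read-out higher numbers stand for weaker inhibition and lower numbers for stronger inhibition), at 10 nM. Going by the values given here, its only measured neighbour is compound 1 `NCc1cc(F)ccc1CN(Cc1nc2ccccc2[nH]1)C1CCCc2cccnc21`, which in this assay gives 219 nM; that pair is the single step recorded, a 22-fold lower number from compound 1 to compound 2 (1.34 log units; beyond the scatter), and it shows how much the aminomethyl group contributes on the shared core.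

Compound 3 `NCc1cc(CO)ccc1CN(Cc1nc2ccccc2[nH]1)C1CCCc2cccnc21` has not yet been measured in this assay. It differs from compound 2 in one place: hydroxy in place of amino on a saturated chain carbon bound to an aromatic carbon. The change touches the same arm whose introduction drove the step from compound 1 to compound 2, so that step bears directly on it. The amino group is lost but the one-heavy-atom chain with a donor and an acceptor remains. The expectation is therefore a move back toward compound 1, that is a higher number, though not the full reversal, so compound 3 is expected at an 8.0-fold higher number from compound 2 to compound 3 (0.90 log units; beyond the scatter) relative to compound 2. In this assay, compound 3 is estimated at 80 nM, within a range of 25 nM to 250 nM.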

Compound 3, half-maximal inhibitory concentration: 11 nM
Compound 3: middle estimate off by 7.3-fold (0.86 log units), on the high side; measured number outside the range, below it.
By their numbers in this assay, from the lowest: compounds 2 and 3 (each within the scatter of the next); then compound 1.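

In this assay, hydroxy in place of amino on a saturated chain carbon bound to an aromatic carbon gives a 1.1-fold higher number from compound 2 to compound 3 (0.04 log units; within the scatter) and this shows that the amino group is not required at this place to hold the low number of compound 2. Against fluoro, hydroxymethyl gives a 20-fold lower number from compound 1 to compound 3 (1.30 log units; beyond the scatter) in the same direction as a 22-fold lower number from compound 1 to compound 2 (1.34 log units; beyond the scatter) so the large step first seen with aminomethyl is not unique to that group and is shared by both chains tested here. The data offer no measurement that accounts for amino and hydroxy giving values within the scatter at this place.

The compounds shown leave open whether the hydroxy hydrogen of hydroxymethyl matters, which methoxymethyl or a plain methyl group would test on the same core. They also leave open how much room this arm allows for other groups, such as a carboxylic acid or a longer chain like hydroxyethyl or aminoethyl, and whether either would stay with compound 2 and compound 3 or move toward compound 1.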